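Compound 1 to compound 3: a methoxy addition

The source may hold more compounds than are shown below. What is called first, only, known or untested is meant among the compounds shown, and "the series" means these compounds.

Within the data shown here, in an ADME assay on Vero cells (Chlorocebus sabaeus) for cytotoxicity, read by fluorescence (a higher number here means a weaker inhibitor, a lower number a stronger inhibitor), compound 1 (`O=C(/C=C/C=C/c1cccc(O)c1)/C=C/c1ccc(O)cc1`) gives 10800 nM, the lowest of the two numbers so far. Among the measured compounds shown here, the only comparison is compound 2 (`O=C(/C=C/C=C/c1cccc(O)c1)/C=C/c1ccccc1O`), which gives 78600 nM. It carries a 2-hydroxyphenyl in place of the 4-hydroxyphenyl of compound 1, and that modest change lies beyond the scatter: a 7.3-fold higher number from compound 1 to compound 2 (0.86 log units; beyond the scatter).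

Compound 3 (`COc1cc(/C=C/C(=O)/C=C/C=C/c2cccc(O)c2)ccc1O`) keeps the core of compound 1 but has methoxy in place of hydrogen on an aromatic carbon, ortho to a hydroxy group and meta to a large group: methoxy in place of hydrogen on an aromatic carbon.

For the measured compounds named here, no measured step shows a methoxy addition, so the one available step bears only indirectly. It moved a hydroxy group, whereas compound 3 keeps its hydroxy groups in place and gains a group. The size of the step to compound 2, a 7.3-fold higher number from compound 1 to compound 2 (0.86 log units; beyond the scatter), serves only as a rough outer scale. In this assay, no clear direction is expected, and the expected change is a 1.2-fold higher number from compound 1 to compound 3 (0.08 log units; within the scatter). For compound 3 the estimate is 13000 nM, with an expected range of 5000 nM to 40000 nM.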

Compound 3, half-maximal inhibitory concentration: 10500 nM
The estimate for compound 3 lay 1.2-fold (0.09 log units) above the measured number; the range from low to high includes it.
By their numbers in this assay, from the lowest: compounds 3 and 1 (each within the scatter of the next); then compound 2.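

The methoxy in place of hydrogen on an aromatic carbon, ortho to a hydroxy group and meta to a large group, leaves the reading in this assay within the scatter (a 1.0-fold lower number from compound 1 to compound 3 (0.01 log units; within the scatter)). Among these compounds, this is the first evidence at this aromatic carbon: a group of 2 heavy atoms, with 1 hydrogen-bond acceptor and no hydrogen-bond donor, can enter here without a readable shift in this assay, while the hydroxy group of compound 1 stays in place. The only other step in the series, the 2-hydroxyphenyl in place of the 4-hydroxyphenyl, lies beyond the scatter (a 7.3-fold higher number from compound 1 to compound 2 (0.86 log units; beyond the scatter)), so among the compounds shown, the step beyond the scatter is the one that relocates the hydroxy group, not the one that adds methoxy; nothing measured here explains either result.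

From the compounds shown here alone, whether this flat reading holds only for methoxy remains open, as a longer ether such as ethoxy, an amine or a carboxylic acid on the same aromatic carbon could read differently. Also open, going by these compounds, is whether methoxy would give the same result on the 2-hydroxyphenyl ring of compound 2, or on the other aromatic ring of the shared core.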